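Trimming the aryl ether: from compound 2 to compound 3

The source may hold more compounds than are shown below. What is called first, only, known or untested is meant among the compounds shown, and "the series" means these compounds.

Compound 1, `COc1cc(C(C)=O)ccc1OCCCN1CCC(C(c2ccc(F)cc2F)c2ccc(F)cc2F)CC1`, gives 15.9 nM in a functional assay (aorta) with Oryctolagus cuniculus as the target; a lower number here means tighter binding, a higher number weaker binding.
Compound 2, `COc1cc(C(C)O)ccc1OCCCN1CCC(C(c2ccc(F)cc2)c2ccc(F)cc2)CC1`, gives 10 nM in this assay.

Compound 2 shows the lower of the two numbers, but its gap to compound 1 lies within the scatter, so neither stands apart. Compound 3, `COc1ccc(OCCCN2CCC(C(c3ccc(F)cc3)c3ccc(F)cc3)CC2)cc1`, has not been measured. It differs from compound 2 in one place: 4-methoxyphenyl in place of 4-(1-hydroxyethyl)-2-methoxyphenyl on an oxygen on a saturated carbon. The hydroxyl donor that compound 2 carries is lost here. For the measured compounds named here, with no comparable step among the measured pairs, a modest weakening in this assay is expected rather than a large one. Compound 3 is therefore estimated at 30 nM, between 8 nM and 120 nM, a step of a 3.0-fold higher number from compound 2 to compound 3 (0.48 log units; beyond the scatter) that is expected to exceed the scatter only slightly.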

Compound 3, dissociation constant: 2.51 nM
Compound 3: the middle estimate sits 12-fold (1.08 log units) above what was measured; the measured number lies below the stated range.
By their numbers in this assay, from the lowest: compound 3; then compounds 2 and 1 (each within the scatter of the next).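

Replacing 4-(1-hydroxyethyl)-2-methoxyphenyl with the smaller 4-methoxyphenyl on this oxygen gives a 4.0-fold lower number from compound 2 to compound 3 (0.60 log units; beyond the scatter) in this assay, a gain that lies beyond the scatter. So at this position, the hydroxyl donor of compound 2 is not required for a low number, and losing it does not weaken the result. Nothing measured here explains the step.

For the compounds shown here, the single step removes the 1-hydroxyethyl group and also changes where the methoxy group stands, so the two changes cannot be separated. Going by these compounds, whether 4-ethoxyphenyl or 4-chlorophenyl would hold the low number of compound 3 also remains open.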